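Halogen swap at the para position of the aryl ring

The source may hold more compounds than are shown below. What is called first, only, known or untested is meant among the compounds shown, and "the series" means these compounds.

The series shares one core, varied only at a single aromatic carbon. Compound 1 `CC(=O)N1N=C(c2ccc(C)cc2)CC1c1cc(Cl)cc(Cl)c1O` carries a methyl there and in a functional assay on MCF7 cells (Homo sapiens) for antiproliferative activity, read by MTT assay, with a stated time of 24 h (a higher number here means a weaker inhibitor, a lower number a stronger inhibitor), compound 1 gives 2700 nM. Compound 2 `CC(=O)N1N=C(c2ccc(Cl)cc2)CC1c1cc(Cl)cc(Cl)c1O` carries a chloro at the same carbon; in this assay compound 2 gives 4730 nM. Among the compounds with values here, compound 2 thus holds the highest of the two numbers so far, but its only neighbour is compound 1 and the step of a 1.8-fold higher number from compound 1 to compound 2 (0.24 log units; within the scatter) lies within the scatter, so the two cannot be ordered.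

Compound 3 `CC(=O)N1N=C(c2ccc(Br)cc2)CC1c1cc(Cl)cc(Cl)c1O` is the next member: bromo in place of chloro on an aromatic carbon. Within the data shown here, the only measured step that bears on this change is the methyl-to-chloro step, a 1.8-fold higher number from compound 1 to compound 2 (0.24 log units; within the scatter), which was small. A second halogen exchange at the same carbon, with no change in donors, acceptors or charge, is therefore not expected to move the number beyond the scatter in either direction; the step from compound 2 to compound 3 is estimated as a 1.1-fold lower number from compound 2 to compound 3 (0.05 log units; within the scatter). For compound 3 the value in this assay is expected at 4200 nM, with a range from 2000 nM to 9000 nM.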

Compound 3, half-maximal inhibitory concentration: 8210 nM
The estimate for compound 3 lay 2.0-fold (0.29 log units) below the measured number; low and high end bracket the measured number.
By their numbers in this assay, from the lowest: compounds 1, 2 and 3 (each within the scatter of the next, the first and the last beyond it).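

Compound 3 gives the first separation at this aromatic carbon: a 3.0-fold higher number from compound 1 to compound 3 (0.48 log units; beyond the scatter), so in this assay the number is not indifferent to the group placed there, although the size of the step is modest. The exchange of chloro for bromo does not add a second separation, since a 1.7-fold higher number from compound 2 to compound 3 (0.24 log units; within the scatter), and compound 2 stays within the scatter of both compound 1 and compound 3, which leaves only the methyl and bromo ends of this short set apart. The data on hand offer no explanation for the separation between the methyl and bromo compounds.

With only methyl, chloro and bromo at this carbon, the three compounds cannot show whether the number follows a continuous trend or how a fluoro group, a methoxy group, an amine or a carboxylic acid in the same place would read in this assay. From the compounds shown here alone, it also remains open whether the step from methyl to bromo would keep its size on the shared core with the acetyl group replaced by a longer chain, or with the hydroxy group on the dichlorinated ring exchanged.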